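The source may report more compounds than this note shows. Statements on the series, on what has been measured and on what is new or still open speak of the compounds shown alone.

Measured in a functional assay on HCT-116 cells (Homo sapiens) for antiproliferative activity, read by MTT assay, with a stated time of 72 h; on this read-out lower numbers stand for stronger inhibition and higher numbers for weaker inhibition:
- compound 1 `O=C(O)c1cccc(NCCOc2ccc3cc2COC/C=C/COCc2cccc(c2)-c2ccnc(n2)N3)c1`: 59200 nM
- compound 2 `O=C(NO)c1cccc(NCCOc2ccc3cc2COC/C=C/COCc2cccc(c2)-c2ccnc(n2)N3)c1`: 2010 nM

Compound 2 has the lower number of the pair. Compound 3 `O=C(CCCCCOc1ccc2cc1COC/C=C/COCc1cccc(c1)-c1ccnc(n1)N2)NO` has not been measured. It differs from compound 2 through (3-(hydroxycarbamoyl)propyl in place of (3-(hydroxycarbamoyl)phenyl)amino on a saturated chain carbon, two bonds along the chain from an oxygen on an aromatic ring), with 3-(hydroxycarbamoyl)propyl in place of (3-(hydroxycarbamoyl)phenyl)amino. Within the data shown here, the only measured step, a 29-fold lower number from compound 1 to compound 2 (1.47 log units; beyond the scatter), is large, but it concerns the carbonyl end, and compounds 2 and 3 both keep hydroxycarbamoyl. Among the measured compounds shown here, no measured step covers the chain exchange, so no step beyond the scatter is expected in this assay, and the direction stays open. The estimated change is a 1.7-fold lower number from compound 2 to compound 3 (0.22 log units; within the scatter). For compound 3 the expected value is 1200 nM, with an expected range of 300 nM to 5000 nM.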

Compound 3, half-maximal inhibitory concentration: 2560 nM
Compound 3: the middle estimate sits 2.1-fold (0.33 log units) below what was measured, within the range that was stated.
By their numbers in this assay, from the lowest: compounds 2 and 3 (each within the scatter of the next); then compound 1.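

In this assay the exchange at this position gives a 1.3-fold higher number from compound 2 to compound 3 (0.11 log units; within the scatter), so the aromatic ring and amino nitrogen of (3-(hydroxycarbamoyl)phenyl)amino can be replaced by 3-(hydroxycarbamoyl)propyl without a step beyond the scatter. Relative to the carboxy-bearing compound 1, the exchange gives a 23-fold lower number from compound 1 to compound 3 (1.36 log units; beyond the scatter), a large step. No measurement at hand gives a reason for either step. Still open, on these data alone, is how a carboxylic acid on the propyl chain would compare with compound 3, and whether a longer chain ending in hydroxycarbamoyl would stay within the scatter of compound 3.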